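From butoxy to butylamino on the shared core

The source may report more compounds than this note shows. Statements on the series, on what has been measured and on what is new or still open speak of the compounds shown alone.

Values in an ADME assay on HFF cells (Homo sapiens) for cytotoxicity, with a stated time of 8 days (a lower number here means that less compound is tolerated, a higher number that more compound is tolerated), each of them a limit and not a number:

Compound 1 `Nc1nc(NC2CCCC2)c2ncn(/C=C3/CC3(CO)CO)c2n1`: > 300000 nM
Compound 2 `CCCCCCOc1nc(N)nc2c1ncn2/C=C1/CC1(CO)CO`: > 200000 nM
Compound 3 `CCCCOc1nc(N)nc2c1ncn2/C=C1/CC1(CO)CO`: > 300000 nM

Compound 3 stands at the limit of > 300000 nM in this assay, at which 2 of the 3 values shown sit, and that is a limit. The next compound, compound 4 `CCCCNc1nc(N)nc2c1ncn2/C=C1/CC1(CO)CO`, carries butylamino in place of butoxy on an aromatic carbon.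

Two measured steps come closest to this change, as both involve the butoxy group of compound 3. One is a step that the two limits leave unreadable from compound 1 to compound 3, which swaps cyclopentylamino for butoxy. The other is a step that the two limits leave unreadable from compound 2 to compound 3, which shortens the chain on the oxygen. Neither has a readable size, so they offer no measured effect to carry over. Compound 1, which carries cyclopentylamino, is the nearest guide and gives the limit > 300000 nM. No clear step is therefore expected in this assay, in either direction. The expected change is a number no higher from compound 3 to compound 4 (the limit leaves the size open). Compound 4 is estimated at 300000 nM, within an expected range from 100000 nM to 500000 nM.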

Compound 4, half-maximal cytotoxic concentration: > 300000 nM
Compound 4 was reported as a limit; the forecaster's own chance of this, stated with the estimate: 70%; the middle value lies on the limit itself.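

In this assay compound 4 gives > 300000 nM, which is a limit. Within the data shown here, with all values limits, no step between compound 4 and compound 1, compound 2 or compound 3 can be read. The compounds shown leave open where each true half-maximal cytotoxic concentration lies, and whether butylamino, butoxy, hexyloxy or cyclopentylamino changes it at all.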